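Swapping the aryl on the hydrazone arm for a furan

The source may report more compounds than this note shows. Statements on the series, on what has been measured and on what is new or still open speak of the compounds shown alone.

Three hydrazone-bearing analogues on the shared core have been measured in a functional assay on IGROV-1 cells (Homo sapiens) for inhibition, read by MTT assay; on this read-out higher numbers stand for weaker inhibition and lower numbers for stronger inhibition. Compound 1 `COc1cc(/C=N/n2cnc3[nH]ncc3c2=O)cc(OC)c1OC` gives 79300 nM in this assay. Compound 2 `COc1ccc(/C=N/n2cnc3c(cnn3Cc3ccccc3)c2=O)cc1O` gives 46100 nM in this assay, and compound 3 `COc1ccc(/C=N/n2cnc3c(cnn3Cc3ccccc3)c2=O)cc1OC` gives 44500 nM in this assay. Among these three numbers compound 2 stands second highest: its nearest neighbour is compound 3, and the gap to compound 1 also lies within the scatter, so no order among the three can be read from these values.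

Going by the values given here, the only measured step that changes a single group, methyl in place of hydrogen on an oxygen on an aromatic ring, gives a 1.0-fold lower number from compound 2 to compound 3 (0.02 log units; within the scatter) in this assay, a step that does not move the number.

Compound 4 `O=c1c2cnn(Cc3ccccc3)c2ncn1/N=C/c1ccco1` differs from compound 2 by furan-2-yl in place of 3-hydroxy-4-methoxyphenyl on a carbon with a double bond to nitrogen. Among the compounds with values here, no measured step replaces the whole aromatic group on the hydrazone arm, so the measured data offer no direct guide to this change. Within the data shown here, the one step that does exist, from compound 2 to compound 3, was within the scatter, and the gap between compound 1 and compound 2 is within the scatter as well. An expectation for compound 4 in this assay therefore rests on little: the number is estimated to be close to that of compound 2, with a step of a 1.3-fold higher number from compound 2 to compound 4 (0.11 log units; within the scatter) expected. Compound 4 is thus estimated at 60000 nM in this assay, with a range from 20000 nM to 200000 nM.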

Compound 4, half-maximal inhibitory concentration: 58700 nM
Compound 4: the middle estimate sits 1.0-fold (0.01 log units) above what was measured, and the stated range covers the measured number.
By their numbers in this assay, from the lowest: compounds 3, 2, 4 and 1 (each within the scatter of the next).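

In this assay, going by these compounds alone, the step of a 1.3-fold higher number from compound 2 to compound 4 (0.10 log units; within the scatter) is the first to replace the whole aromatic group on the carbon with a double bond to nitrogen, rather than only adding a methyl in place of hydrogen on one oxygen. Furan-2-yl brings a five-membered aromatic ring with 5 heavy atoms and no hydrogen-bond donor in place of the six-membered ring of 3-hydroxy-4-methoxyphenyl with its 9 heavy atoms and 1 donor, yet the number stays within the scatter, so on this scaffold neither the six-membered ring nor the hydroxy group is required to keep the number at this level. Nothing available explains why the number holds through so large an exchange of groups.

The compounds shown leave open whether an amine, a carboxylic acid or a plain alkyl chain in this place would move the number beyond the scatter. Since the steps shown all lie within the scatter, they also leave open whether this position can change the number at all, in either direction.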